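This account rests on a few compounds, and the source may have more. Where it says the series, first, only, none or still open, it means among the compounds named here.

Notes on the series. In a functional assay on DU-145 cells (Homo sapiens) for inhibition, read by trypan blue exclusion, with a stated time of 96 h (a lower number here means a stronger inhibitor of growth, a higher number a weaker inhibitor of growth), compound 1 `O=C(/C(=C\c1ccccc1F)S(=O)(=O)c1ccc(Br)cc1)c1ccc(Cl)cc1` gives 25000 nM, compound 2 `O=C(O)c1ccc(C(=O)/C(=C\c2ccc(F)c([N+](=O)[O-])c2)SCc2ccc(C(F)(F)F)cc2)cc1` gives 1000 nM, and compound 3 `COc1cc(OC)c(/C=C(/C(=O)c2ccc(Cl)cc2)[S+]([O-])Cc2ccccc2Cl)c(OC)c1` gives 10000 nM. Compound 3 stands second highest of the three numbers: below compound 1, above compound 2, both gaps beyond the scatter. Compound 4 `COc1cc(OC)c(/C=C(\SCc2ccccc2Cl)C(=O)c2ccc(Cl)cc2)c(OC)c1` has not yet been measured in this assay. Compound 4 differs from compound 3 at one place: a group of 9 heavy atoms (7 carbon, 1 sulfur, 1 chlorine; one six-membered aromatic ring of carbon only) in place of a group of 10 heavy atoms (7 carbon, 1 oxygen, 1 sulfur, 1 chlorine; one six-membered aromatic ring of carbon only), on a double-bonded chain carbon bound to a carbonyl carbon and a double-bonded chain carbon. Among the measured compounds shown here, no measured pair in the set shares this change. Compound 2, the one sulfide measured, gives 1000 nM, but it differs from compound 3 in several other places, so it is only a loose pointer. The step of a 2.0-fold lower number from compound 3 to compound 4 (0.30 log units; within the scatter) is expected to be a modest lowering, not far beyond the scatter. Compound 4 is estimated at 5000 nM, within 1500 nM to 20000 nM.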

Compound 4, concentration for 50% growth inhibition: 25000 nM
For compound 4 the middle estimate is 5.0-fold (0.70 log units) below the measured one, and the stated range ends below it.
By their numbers in this assay, from the lowest: compound 2; then compound 3; then compounds 1 and 4 (each within the scatter of the next).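

Among the compounds shown here, this is the first one-place comparison: at the double-bonded chain carbon bound to a carbonyl carbon and a double-bonded chain carbon, (2-chlorobenzyl)sulfanyl in place of the oxygen-bearing group of compound 3 gives a 2.5-fold higher number from compound 3 to compound 4 (0.40 log units; beyond the scatter) in this series. The oxygen at this sulfur therefore goes with the lower number on this core, though the step is modest. Nothing at hand accounts for the step.

From the compounds shown here alone, whether the step holds on other cores stays open. So does how an amine or a longer chain at this position would read.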